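Replacing a methylpiperazine with a pyridine ring on the shared core

The source may hold more compounds than are shown below. What is called first, only, known or untested is meant among the compounds shown, and "the series" means these compounds.

Measured compounds:
- compound 1 `C[C@H](Oc1ccc(S(C)(=O)=O)cc1C(=O)N1Cc2ccccc2C1)C(F)(F)F`, in an assay on CHO cells for inhibition of sodium- and chloride-dependent glycine transporter 1 (Homo sapiens), read by scintillation counting (on this read-out lower numbers stand for an effect already at smaller amounts and higher numbers for an effect only at larger amounts of compound), compound 1 gives 2540 nM
- compound 2 `COc1ccc2c(c1)CN(C(=O)c1cc(S(C)(=O)=O)ccc1O[C@@H](C)C(F)(F)F)C2`, in this assay compound 2 gives 180 nM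
- compound 3 `C[C@H](Oc1ccc(S(C)(=O)=O)cc1C(=O)N1Cc2ccc(N3CCN(C)CC3)cc2C1)C(F)(F)F`, in this assay compound 3 gives 2080 nM

Among these three numbers compound 3 stands second highest. Its nearest neighbour is compound 1, whose number is only slightly higher: a 1.2-fold lower number from compound 1 to compound 3 (0.09 log units; within the scatter). Its furthest neighbour is compound 2, which gives a much lower number: a 12-fold higher number from compound 2 to compound 3 (1.06 log units; beyond the scatter). The third comparison, a 14-fold lower number from compound 1 to compound 2 (1.15 log units; beyond the scatter), shows how much the methoxy group contributes at this position.

Compound 4 `C[C@H](Oc1ccc(S(C)(=O)=O)cc1C(=O)N1Cc2ccc(-c3ccccn3)cc2C1)C(F)(F)F` differs from compound 3 in one place: pyridin-2-yl in place of 4-methylpiperazin-1-yl on an aromatic carbon. Within the data shown here, two measured steps bear on this. The step from the unsubstituted core to the methylpiperazine was within the scatter, while the step from methoxy to methylpiperazine was large. The incoming pyridin-2-yl is neither a small methoxy nor a saturated ring bearing a second nitrogen, so the measured steps give only loose guidance. The expectation is a modest move toward lower numbers in this assay, with wide uncertainty: for compound 4 the estimated step is a 2.1-fold lower number from compound 3 to compound 4 (0.32 log units; beyond the scatter). Compound 4 is therefore expected at about 1000 nM, within a range from 250 nM to 4000 nM.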

Compound 4, half-maximal effective concentration in the sodium- and chloride-dependent glycine transporter 1 assay: 84 nM
For compound 4 the middle estimate is 12-fold (1.08 log units) above the measured one; the measured number lies below the stated range.
By their numbers in the sodium- and chloride-dependent glycine transporter 1 assay, from the lowest: compound 4; then compound 2; then compounds 3 and 1 (each within the scatter of the next).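

In the sodium- and chloride-dependent glycine transporter 1 assay, this aromatic carbon of the shared core turns out to respond strongly to a large group, not only to methoxy: a 25-fold lower number from compound 3 to compound 4 (1.39 log units; beyond the scatter), and a 30-fold lower number from compound 1 to compound 4 (1.48 log units; beyond the scatter). Size alone does not settle the outcome, as two six-membered rings at the same place give very different numbers, and in the sodium- and chloride-dependent glycine transporter 1 assay pyridin-2-yl also goes beyond methoxy, with a 2.1-fold lower number from compound 2 to compound 4 (0.33 log units; beyond the scatter). The same exchange of rings comes with a loss in a physicochemical assay for solubility; a higher number here means a more soluble compound, a lower number a less soluble compound: the measured solubility of compound 3, 490 ug/mL, and of compound 4, 30 ug/mL, a 16-fold lower number (1.21 log units; beyond the scatter). In the physicochemical assay compound 3 gives 490 ug/mL, and compound 4 gives 30 ug/mL.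

Still open, going by these compounds, is whether the ring nitrogen of pyridin-2-yl matters, which a plain phenyl ring or a pyridin-3-yl ring at this place would test. Also open, on these data alone, is whether a ring such as morpholin-4-yl could give both a low number in the sodium- and chloride-dependent glycine transporter 1 assay and a high number in the physicochemical assay.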